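This account rests on a few compounds, and the source may have more. Where it says the series, first, only, none or still open, it means among the compounds named here.

For the measured compounds named here, compound 1 `COc1ccc(S(=O)(=O)NC(=O)NC/C=C2\CCCc3cnn(Cc4ccc(Cl)cc4Cl)c32)cc1` is one of three compounds measured so far in an assay on isolated protein for displacement of a labelled ligand from prostaglandin E2 receptor EP3 subtype (Homo sapiens), read by scintillation counting, with a stated time of 2 h; on this read-out lower numbers stand for stronger inhibition and higher numbers for weaker inhibition. In this assay compound 1 gives 10 nM, the second highest of the three numbers. Compound 2 `O=C(NC/C=C1\CCCc2cnn(Cc3ccc(Cl)cc3Cl)c21)NS(=O)(=O)c1cccs1` gives 15 nM, and compound 3 `O=C(NS(=O)(=O)c1cc(Cl)c(Cl)s1)OC/C=C1\CCCc2cnn(Cc3ccc(Cl)cc3Cl)c21` gives 1 nM; compound 3 differs from compound 1 in more than one place, so its number alone says nothing about any single change. Compound 4 `COc1ccc(Cl)cc1S(=O)(=O)NC(=O)NC/C=C1\CCCc2cnn(Cc3ccc(Cl)cc3Cl)c21` differs from compound 1 in one place: 5-chloro-2-methoxyphenyl in place of 4-methoxyphenyl on a sulfonyl sulfur. Going by the values given here, the only measured step at the same sulfonyl sulfur, a 1.5-fold higher number from compound 1 to compound 2 (0.18 log units; within the scatter), stayed within the scatter, so little movement is expected here either. For compound 4 the expected step is no change at the digits printed from compound 1 to compound 4 (within the scatter). The estimate for compound 4 is 10 nM, with a range from 3 nM to 30 nM.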

Compound 4, inhibition constant: 3 nM
Compound 4: middle estimate off by 3.3-fold (0.52 log units), on the high side; measured number inside the range.
By their numbers in this assay, from the lowest: compound 3; then compound 4; then compounds 1 and 2 (each within the scatter of the next).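

The aryl group on the sulfonyl sulfur is less silent than the thiophen-2-yl swap suggested: in this assay 5-chloro-2-methoxyphenyl gives a 3.3-fold lower number from compound 1 to compound 4 (0.52 log units; beyond the scatter) and thus a step beyond the scatter. Set against thiophen-2-yl, the same group gives a 5.0-fold lower number from compound 2 to compound 4 (0.70 log units; beyond the scatter) and so shows that this position can move the number. Nothing measured here accounts for these steps. The new group differs from 4-methoxyphenyl both by its chlorine and by where its methoxy sits, and the compounds shown do not separate the two. On these data alone, how a plain phenyl or a chlorophenyl with no methoxy would read at this position also stays open.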